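Carbamoyl in Place of Methoxy: Expected Tolerance of Compound 4

The compounds below may be only part of what the source reports. "The series", "measured", "known", "first", "only" and "open" are said of these compounds alone.

Of the compounds shown here, three built on one shared core have been tested in a functional assay on HEL cells (Homo sapiens); a lower number here means that less compound is tolerated, a higher number that more compound is tolerated. Compound 1 `CCNC(=O)NC1=CS(=O)(=O)O[C@@]12[C@@H](CO[Si](C)(C)C(C)(C)C)O[C@@H](n1cc(C)c(=O)n(C)c1=O)[C@@H]2O[Si](C)(C)C(C)(C)C` gives 10000 nM in this assay. Compound 2 `Cc1cn([C@@H]2O[C@H](CO[Si](C)(C)C(C)(C)C)[C@@]3(OS(=O)(=O)C=C3NC(N)=O)[C@H]2O[Si](C)(C)C(C)(C)C)c(=O)n(C)c1=O` gives 11000 nM. Compound 3 `COC(=O)CNC1=CS(=O)(=O)O[C@@]12[C@@H](CO[Si](C)(C)C(C)(C)C)O[C@@H](n1cc(C)c(=O)n(C)c1=O)[C@@H]2O[Si](C)(C)C(C)(C)C` gives 160000 nM, the highest of the three numbers, so more of compound 3 is tolerated than of either other compound, as the steps of a 16-fold higher number from compound 1 to compound 3 (1.20 log units; beyond the scatter) and a 15-fold higher number from compound 2 to compound 3 (1.16 log units; beyond the scatter) show. The step of a 1.1-fold higher number from compound 1 to compound 2 (0.04 log units; within the scatter) adds nothing beyond the scatter.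

Compound 4 `Cc1cn([C@@H]2O[C@H](CO[Si](C)(C)C(C)(C)C)[C@@]3(OS(=O)(=O)C=C3NCC(=O)C(N)=O)[C@H]2O[Si](C)(C)C(C)(C)C)c(=O)n(C)c1=O` differs from compound 3 by carbamoyl in place of methoxy on a carbonyl carbon. Among the measured compounds shown here, none of the measured steps alters this carbonyl carbon; the two large steps concern the amine nitrogen, where the group that enters in compound 4 resembles what compound 2 carries. The expected step is therefore a 2.7-fold lower number from compound 3 to compound 4 (0.43 log units; beyond the scatter), a modest move back toward the numbers of compounds 1 and 2, with wide uncertainty. Compound 4 is estimated to give 60000 nM in this assay, with a range from 15000 nM to 200000 nM.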

Compound 4, half-maximal cytotoxic concentration: 14500 nM
The estimate for compound 4 lay 4.1-fold (0.62 log units) above the measured number, outside the stated range (below it).
By their numbers in this assay, from the lowest: compounds 1, 2 and 4 (each within the scatter of the next); then compound 3.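

In this assay the exchange of methoxy for carbamoyl on a carbonyl carbon is a large step on its own, with an 11-fold lower number from compound 3 to compound 4 (1.04 log units; beyond the scatter) for this single change. The earlier steps shown here replaced the whole group on the amine nitrogen, so they could not show that the high number of compound 3 is lost when only the methoxy of its (methoxycarbonyl)methyl group is exchanged. With (carbamoylcarbonyl)methyl on the amine nitrogen, the steps of a 1.3-fold higher number from compound 2 to compound 4 (0.12 log units; within the scatter) and a 1.5-fold higher number from compound 1 to compound 4 (0.16 log units; within the scatter) both lie within the scatter, so of these four compounds only compound 3 stands apart.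

Still open, from the compounds shown here alone, is whether ethoxy, a hydroxyl giving the carboxylic acid, or a dimethylamino group on that carbonyl carbon would keep the number of compound 3 or lose it. Nothing given here explains the size of this step.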